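The compounds below may be only part of what the source reports. "The series", "measured", "known", "first", "only" and "open" are said of these compounds alone.

Compound 3 `N[C@H]1CC[C@@H](C(=O)Nc2cc3cc[nH]c(=O)c3cc2Cl)CC1` gives 1.17 h in an in vitro ADME assay on microsomes from liver (Homo sapiens) for metabolic stability, tested at 1 mg/mL (on this read-out lower numbers stand for a shorter-lived compound and higher numbers for a longer-lived compound), the second highest of the three numbers in hand. Compound 2 `CC(C)[C@H](N)C(=O)Nc1cc2cc[nH]c(=O)c2cc1Cl` stands nearest with 1.48 h, while compound 1 `CC(C)N[C@H](C(=O)Nc1cc2cc[nH]c(=O)c2cc1Cl)C1CCCCC1` gives 0.283 h, the furthest of the set. Compound 4 `O=C(Nc1cc2cc[nH]c(=O)c2cc1Cl)[C@H]1CCCN1` differs from compound 3 by pyrrolidin-2-yl in place of 4-aminocyclohexyl on a carbonyl carbon. Going by the values given here, the only measured step that bears on a change at this carbonyl carbon is a 1.3-fold lower number from compound 2 to compound 3 (0.10 log units; within the scatter), where one amine-bearing group was exchanged for another without leaving the scatter. On that basis the exchange of one amine-bearing ring for another is expected to give a 1.2-fold lower number from compound 3 to compound 4 (0.07 log units; within the scatter), nothing beyond the scatter. Compound 4 is therefore estimated at 1 h, with a range from 0.4 h to 2.5 h in this assay.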

Compound 4, half-life: 0.283 h
For compound 4 the middle estimate is 3.5-fold (0.55 log units) above the measured one; measured number below the stated range.
By their numbers in this assay, from the lowest: compounds 1 and 4 (each within the scatter of the next); then compounds 3 and 2 (each within the scatter of the next).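

At this carbonyl carbon, the choice of amine-bearing group does shift the half-life in this assay: pyrrolidin-2-yl in place of 4-aminocyclohexyl gives a 4.1-fold lower number from compound 3 to compound 4 (0.62 log units; beyond the scatter) and pyrrolidin-2-yl in place of 1-amino-2-methylpropyl gives a 5.2-fold lower number from compound 2 to compound 4 (0.72 log units; beyond the scatter). The earlier exchange of 1-amino-2-methylpropyl for 4-aminocyclohexyl had stayed within the scatter, so not every amine-bearing group is interchangeable here. Nothing measured accounts for the lower numbers. Still open, as far as these compounds go, is whether the five-membered ring itself or the placing of its nitrogen sets the result. A piperidin-2-yl group at this carbonyl carbon would help separate the two.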